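The source may report more compounds than this note shows. Statements on the series, on what has been measured and on what is new or still open speak of the compounds shown alone.

Compound 1 `COC(=O)C[C@H](NC(=O)OC(C)(C)C)C(=O)N(Cc1ccccc1)C1(C(=O)NCc2ccccc2)CCN(Cc2ccccc2)CC1`: 20000 nM in a functional assay on HeLa cells (Homo sapiens) for inhibition, with a stated time of 72 h; a lower number here means a stronger inhibitor, a higher number a weaker inhibitor
Compound 2 `COC(=O)C[C@H](NC(=O)OC(C)(C)C)C(=O)N(Cc1ccccc1)C1(C(=O)NCc2ccccc2)CCNCC1`: > 167000 nM in this assay
Compound 3 `CCC(C)N(C(=O)[C@@H](N)CC(=O)OC)C1(C(=O)NCc2ccccc2)CCN(Cc2ccccc2)CC1`: > 250000 nM in this assay

Compound 1 gives 20000 nM in this assay. For compound 2 the value > 167000 nM is a limit of the assay and not a number. The step between them, an at least 8.3-fold higher number from compound 1 to compound 2 (0.92 log units; beyond the scatter), comes from the change (hydrogen in place of benzyl on an amine nitrogen in a ring), and its size is bounded by the limit of > 167000 nM in this assay, at which 1 of the 3 values shown sits. For compound 3 the value > 250000 nM is likewise a limit, at the limit of > 250000 nM in this assay, at which 1 of the 3 values shown sits. The difference between the core of compound 1 and the core of compound 3 is not broken down here.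

Compound 4 `CCC(C)N(C(=O)[C@@H](N)CC(=O)OC)C1(C(=O)NCc2ccccc2)CCNCC1` is not yet measured. It differs from compound 3 by hydrogen in place of benzyl on an amine nitrogen in a ring, the same change as from compound 1 to compound 2, at a place described in the same words. Since compound 3 already sits at a limit, compound 4 is expected to remain at or beyond that limit, the estimated step being a step that the limit leaves unreadable from compound 3 to compound 4; this expectation rests on the step of an at least 8.3-fold higher number from compound 1 to compound 2 (0.92 log units; beyond the scatter). Compound 4 is therefore estimated at 600000 nM, between 200000 nM and 3000000 nM.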

Compound 4, half-maximal inhibitory concentration: > 250000 nM
Compound 4 was reported as a limit; the forecaster's own chance of this, stated with the estimate: 95%; the middle value is on the limit's open side.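

Going by these compounds alone, compound 3 and compound 4 both stand at limits of this assay and not at numbers, so no step between them can be read. The compounds shown leave open whether hydrogen in place of benzyl on an amine nitrogen in a ring changes the read-out on the core of compound 3, as it does on the core of compound 1.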